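This account rests on a few compounds, and the source may have more. Where it says the series, first, only, none or still open, it means among the compounds named here.

Measured compounds:
- Compound 1, `CCOc1ccc(/C=C/C(=O)Nc2nc(-c3c(C)cc(C)cc3C)cs2)cc1`: 2480 nM
- Compound 2, `Cc1cc(C)c(-c2csc(NC(=O)/C=C/c3ccc(C4CC4)cc3)n2)c(C)c1`: 380 nM

In a functional assay on K562 cells (Homo sapiens) for inhibition, read by MTT assay, with a stated time of 96 h (a lower number here means a stronger inhibitor, a higher number a weaker inhibitor), compound 1 gives the highest of the two numbers shown; the nearest compound is compound 2, reached by the step of a 6.5-fold lower number from compound 1 to compound 2 (0.81 log units; beyond the scatter).

Compound 3, `Cc1cc(C)c(-c2csc(NC(=O)/C=C/c3ccc(N4CCCCC4)cc3)n2)c(C)c1`, has not yet been measured in this assay. It differs from compound 1 by piperidin-1-yl in place of ethoxy on an aromatic carbon. Within the data shown here, the only measured step that bears on this change is the one at the same position, a 6.5-fold lower number from compound 1 to compound 2 (0.81 log units; beyond the scatter), where one group replaced ethoxy on the aromatic carbon and the number fell by a modest amount beyond the scatter. Compound 3 carries a different replacement at that same position, so the direction of that step is the guide, while its size is uncertain. Compound 3 is therefore expected to give a lower number than compound 1 in this assay, a step of a 3.1-fold lower number from compound 1 to compound 3 (0.49 log units; beyond the scatter), with an estimated value of 800 nM, in the range 250 nM to 2500 nM.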

Compound 3, half-maximal inhibitory concentration: 4060 nM
Compound 3: middle estimate off by 5.1-fold (0.71 log units), on the low side; measured number above the stated range.
By their numbers in this assay, from the lowest: compound 2; then compounds 1 and 3 (each within the scatter of the next).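

In this assay, the drop seen with cyclopropyl does not extend to every replacement of ethoxy on this aromatic carbon: with piperidin-1-yl the result is a 1.6-fold higher number from compound 1 to compound 3 (0.21 log units; within the scatter), so compound 3 cannot be told apart from compound 1. The position is still sensitive to the group it carries, since exchanging cyclopropyl for piperidin-1-yl at the same place gives an 11-fold higher number from compound 2 to compound 3 (1.03 log units; beyond the scatter). Nothing given here accounts for this difference between the two groups.

The compounds shown leave open whether the stronger result belongs to cyclopropyl alone or would also appear with an isopropyl or cyclobutyl group. They also leave open whether an open-chain amine such as dimethylamino, or a morpholin-4-yl ring, would give a number close to that of compound 3.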